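Swapping methoxy for fluoro in a weakly cytotoxic series

The source may report more compounds than this note shows. Statements on the series, on what has been measured and on what is new or still open speak of the compounds shown alone.

In an ADME assay on HEK293 cells (Homo sapiens) for cytotoxicity, read by MTT assay, with a stated time of 72 h (on this read-out lower numbers stand for stronger inhibition and higher numbers for weaker inhibition), compound 1 (`O=C(CN1CCN(C(=O)c2cccc(F)c2)CC1)N1CCN(CCCc2c[nH]c3ccccc23)CC1`) gives 182000 nM. Compound 2 (`O=C(CN1CCN(C(=O)c2cccc(F)c2)CC1)N1CCN(CCCc2c[nH]c3ccc(F)cc23)CC1`) gives 83000 nM. Compound 3 (`COc1cccc(C(=O)N2CCN(CC(=O)N3CCN(CCCc4c[nH]c5ccc(OC)cc45)CC3)CC2)c1`) gives > 200000 nM, which is a limit of the assay and not a number. It thus stands at the limit of > 200000 nM in this assay, at which 1 of the 3 values shown sits.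

Compound 4 (`COc1ccc2[nH]cc(CCCN3CCN(C(=O)CN4CCN(C(=O)c5cccc(F)c5)CC4)CC3)c2c1`) is still unmeasured. It differs from compound 3 by fluoro in place of methoxy on an aromatic carbon, turning 3-methoxyphenyl into 3-fluorophenyl: fluoro in place of methoxy on an aromatic carbon.

For the measured compounds named here, the only measured step is a 2.2-fold lower number from compound 1 to compound 2 (0.34 log units; beyond the scatter), with fluoro in place of hydrogen on an aromatic carbon. That is a different replacement, so it bears on this one only loosely. Compound 4 shares its 3-fluorophenyl group with compound 1, which gives 182000 nM, and with compound 2, which gives 83000 nM. A modest move to a lower number is therefore expected, with the expected change being an at least 1.4-fold lower number from compound 3 to compound 4 (0.15 log units; that floor lies within the scatter). For compound 4 the estimated value is 140000 nM, with an expected range from 70000 nM to 250000 nM.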

Compound 4, half-maximal inhibitory concentration: > 200000 nM
Compound 4: a limit, no number (the forecaster's own chance of this, stated with the estimate: 30%); at least 1.4-fold (0.15 log units) between middle value and limit.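

Compound 3 and compound 4 both sit at a limit of the assay in this assay, so the step between them cannot be read, and the 3-fluorophenyl group alone did not bring compound 4 under that limit: the limit of > 200000 nM in this assay, at which 2 of the 4 values shown sit.

The readable contrast lies in the other aromatic substituent of compound 4, where methoxy in place of fluoro gives an at least 2.4-fold higher number from compound 2 to compound 4 (0.38 log units; beyond the scatter), while methoxy in place of hydrogen gives an at least 1.0-fold higher number from compound 1 to compound 4 (0.04 log units; that floor lies within the scatter). Only the first of these steps is beyond the scatter, so fluoro and methoxy are told apart there, while the change from 3-methoxyphenyl to 3-fluorophenyl leaves no readable size.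

From the compounds shown here alone, how far compound 3 and compound 4 lie past the limit stays open. So does whether an amine or a carboxylic acid in place of the fluoro on the 3-fluorophenyl group would give a readable number.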